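Replacing the fluorinated pyridyl in a solubility series

The compounds below may be only part of what the source reports. "The series", "measured", "known", "first", "only" and "open" are said of these compounds alone.

The series shares one core, carried through compound 1 `NS(=O)(=O)c1ccc(-c2ccc3nccc(-c4ccncc4)c3n2)cc1`, compound 2 `CS(=O)(=O)Nc1ccc2nccc(-c3ccncc3)c2n1` and compound 3 `NS(=O)(=O)c1cccc(-c2ccc3nccc(-c4ccncc4F)c3n2)c1`. In a physicochemical assay for solubility, read by HPLC, using the shake flask method, measured as kinetic solubility, with a stated time of 20 h, at pH 6.5, tested at 200 uM (on this read-out lower numbers stand for lower solubility and higher numbers for higher solubility), compound 1 gives 25000 nM. In this assay compound 2 gives 90000 nM. For compound 3 the assay reports only a limit, < 5000 nM, rather than a number. Within the data shown here, this limit of the assay, (the limit of < 5000 nM in this assay, at which 1 of the 3 values shown sits), is where compound 3 stands among the three values shown, and no step between any two measured compounds is recorded here.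

The unmeasured compound 4 `NS(=O)(=O)c1cccc(-c2ccc3nccc(-c4cccnc4)c3n2)c1` differs from compound 3 in one place: pyridin-3-yl in place of 3-fluoropyridin-4-yl on an aromatic carbon. Among the measured compounds shown here, since no measured pair follows this change, the size of its effect is open. The account expects the step from compound 3 to compound 4 in this assay to be small and, if anything, upward, most likely within the usual scatter of the assay rather than clearly beyond it, and it is estimated as a number no lower from compound 3 to compound 4 (the limit leaves the size open). On that basis compound 4 is expected to give about 5000 nM in this assay, with a range of 2000 nM to 15000 nM, and with a fair chance that the assay again reports only its lower limit.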

Compound 4, solubility: < 5000 nM
Compound 4: only a limit was reported; the forecaster's own chance of this, stated with the estimate: 50%; the middle value lies on the limit itself.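

In this assay compound 4 gives < 5000 nM, which is a limit of the assay and not a number. Compound 3 also carries a limit, so no step can be read between compound 3 and compound 4. The compounds shown leave open how far pyridin-3-yl and 3-fluoropyridin-4-yl differ on this read-out, as both values rest on one limit: the limit of < 5000 nM in this assay, at which 2 of the 4 values shown sit.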